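Swapping one saturated ring group for another on compound 1

The source may report more compounds than this note shows. Statements on the series, on what has been measured and on what is new or still open speak of the compounds shown alone.

Measured so far:
compound 1 `CC[C@@H]1C[C@H](CC)CN(CCCNC(=O)C2CCN(Cc3nc(-c4ccccc4C)oc3C)CC2)C1` gives 0.0917 h
compound 2 `CC[C@@H]1C[C@H](CC)CN(CCCNC(=O)C2CCN(Cc3nc(-c4c(F)cccc4F)oc3C)CC2)C1` gives 0.065 h

Both numbers come from an ADME assay on microsomes from liver (Rattus norvegicus) for metabolic stability, read by LC-MS, using NADPH, at 37 degrees C; a lower number here means that the compound disappears faster, a higher number that the compound lasts longer. Compound 1 stands highest of the two numbers, but the step of a 1.4-fold lower number from compound 1 to compound 2 (0.15 log units; within the scatter) is within the scatter, so the two compounds cannot be set in order. Compound 3 `Cc1ccccc1-c1nc(CN2CCC(C(=O)NCCCN3CCCC(CC(C)C)C3)CC2)c(C)o1` is not yet measured; it differs from compound 1 by a group of 10 heavy atoms (9 carbon, 1 nitrogen; one six-membered non-aromatic ring with 1 hetero atom) in place of a group of 10 heavy atoms (9 carbon, 1 nitrogen; one six-membered non-aromatic ring with 1 hetero atom), on a saturated chain carbon, three bonds along the chain from an amide-type nitrogen. The leaving group is 3,5-diethylpiperidin-1-yl; the entering group has no common name. For the measured compounds named here, the single measured step concerns a change on an aromatic carbon and says nothing about exchanging one six-membered non-aromatic ring group for another. Going by the values given here, with no relevant step to lean on, the expectation in this assay is no step beyond the scatter, a 1.0-fold lower number from compound 1 to compound 3 (0.01 log units; within the scatter). Compound 3 is therefore estimated at 0.09 h, with a range of 0.045 h to 0.18 h.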

Compound 3, half-life: 0.0383 h
The estimate for compound 3 lay 2.3-fold (0.37 log units) above the measured number, and the stated range ends above it.
By their numbers in this assay, from the lowest: compounds 3, 2 and 1 (each within the scatter of the next, the first and the last beyond it).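

In this assay, the group on the saturated chain carbon, three bonds along the chain from an amide-type nitrogen, can shift the result, and the exchange gives a 2.4-fold lower number from compound 1 to compound 3 (0.38 log units; beyond the scatter) as a modest step. The two groups hold the same atoms, joined differently, so an unchanged atom count in this group does not guarantee an unchanged half-life, although the leaving 3,5-diethylpiperidin-1-yl also has 2 defined stereocentres and the entering group is listed with none. Nothing measured here accounts for the step.

The compounds shown leave open whether a plain piperidin-1-yl or a morpholin-4-yl at this place would fall nearer compound 1 or compound 3. They also leave open whether the same exchange on compound 2, with its 2,6-difluorophenyl group, would give a similar step.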